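This account rests on a few compounds, and the source may have more. Where it says the series, first, only, none or still open, it means among the compounds named here.

For the measured compounds named here, compound 1 `COc1ccc2c(c1)OC(c1cccc([N+](=O)[O-])c1)C(c1ccccc1)C2=O` and compound 2 `CCOc1ccc2c(c1)OC(c1ccccc1)C(c1ccccc1)C2=O` are the two compounds measured so far. In an ADME assay on PBMC cells (Homo sapiens) for cytotoxicity, read by MTT assay, with a stated time of 5 days (on this read-out higher numbers stand for lower toxicity in this test and lower numbers for higher toxicity in this test), compound 1 gives > 2500000 nM, which is a limit of the measurement rather than a number. In this assay compound 2 likewise gives > 2500000 nM, again only a limit. Going by the values given here, compound 2 therefore stands where every value so far stands, since (the limit of > 2500000 nM in this assay, at which 2 of the 2 values shown sit). Compound 3 `CCOc1ccc2c(c1)OC(c1cccc([N+](=O)[O-])c1)C(c1ccccc1)C2=O` differs from compound 2 by nitro in place of hydrogen on an aromatic carbon, meta to a large group. Among the compounds with values here, no step between measured compounds exists to show what this change does here; compound 1 carries the same nitro group and also sits at the limit. In this assay no step beyond the usual scatter is expected, and the step from compound 2 to compound 3 is estimated at a number no higher from compound 2 to compound 3 (the limit leaves the size open). Compound 3 is expected to give about 2500000 nM, between 1000000 nM and 5000000 nM, most likely again reported only as a limit.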

Compound 3, half-maximal cytotoxic concentration: > 2500000 nM
Compound 3 gave a limit, no number (the forecaster's own chance of this, stated with the estimate: 85%); the middle value lies on the limit itself.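

In this assay, neither the step from compound 2 to compound 3 nor that from compound 1 to compound 3 can be read, since all three compounds stop at a limit: the limit of > 2500000 nM in this assay, at which 3 of the 3 values shown sit.

The compounds shown leave open whether nitro or methyl changes this read-out at all, and at what concentration any of them would show cytotoxicity.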